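The source may hold more compounds than are shown below. What is called first, only, known or untested is meant among the compounds shown, and "the series" means these compounds.

Three compounds built on one shared core have reached an ADME assay on HUVEC cells (Homo sapiens) for cytotoxicity, read by MTT assay, with a stated time of 72 h; a lower number here means a stronger inhibitor, a higher number a weaker inhibitor. For compound 1 `CCCCCn1ccnc1-c1cc(OC)c(OC)c(OC)c1` the entry reads "not determined" (no result reported), so it offers no number. Compound 2 `COc1cc(-c2nccn2-c2ccc(C)cc2)cc(OC)c1OC` gives > 100000 nM, which is a limit of the assay and not a number. Compound 3 `COc1cc(-c2nccn2-c2ccc(Br)cc2)cc(OC)c1OC` gives > 100000 nM, which is likewise a limit and not a number. Compound 3 therefore has no measured potency of its own, and the record so far comes down to the limit of > 100000 nM in this assay, at which 2 of the 3 values shown sit.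

Compound 4 `COc1ccc(-n2ccnc2-c2cc(OC)c(OC)c(OC)c2)cc1` departs from compound 3 in one place: methoxy in place of bromo on an aromatic carbon. This puts methoxy in place of bromo on an aromatic carbon, para to a large group, turning 4-bromophenyl into 4-methoxyphenyl.

Among the measured compounds shown here, the one measured step that bears on this change is a step that the two limits leave unreadable from compound 2 to compound 3, with bromo in place of methyl on an aromatic carbon. No size can be carried over from that step, so no shift beyond the usual scatter is expected in this assay, in either direction. The expected change is a number no higher from compound 3 to compound 4 (the limit leaves the size open), and this estimate is a rough one. Compound 4 is estimated at 100000 nM, with an expected range from 20000 nM to 200000 nM, and it may well report only a limit.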

Compound 4, half-maximal inhibitory concentration: > 50000 nM
Compound 4 gave a limit, no number; the forecaster's own chance of this, stated with the estimate: 75%; the middle value does not contradict the limit.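

In this assay compound 4 gives > 50000 nM, which is a limit and not a number. The steps linking compound 2, compound 3 and compound 4 therefore cannot be read. The compounds shown leave open whether any of them has a measurable value in this assay, and how methyl, bromo and methoxy compare there.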